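The source may report more compounds than this note shows. Statements on the series, on what has been measured and on what is new or still open speak of the compounds shown alone.

Series notes. Compound 3 `CC1CCC(C(=O)N2CC(c3nc(-c4cccc(Cl)c4)no3)C2)CC1` stands at the assay floor in an assay on HEK293 cells for negative allosteric modulation of metabotropic glutamate receptor 5 (Homo sapiens), read by FLIPR; on this read-out lower numbers stand for stronger inhibition and higher numbers for weaker inhibition: compound 3 gives > 10000 nM, a limit rather than a number. Compound 1 `O=C(c1ccc(Cl)cc1)N1CC(c2nc(-c3cccc(F)c3)no2)C1` likewise returns only a limit in this assay, > 10000 nM. Going by the values given here, compound 2 `O=C(c1ccccc1F)N1CC[C@H]1c1nc(-c2cccc(F)c2)no1` is the one member with a measured number, and in this assay compound 2 gives 920 nM. The series as a whole is marked by the limit of > 10000 nM in this assay, at which 2 of the 3 values shown sit. Compound 4 `O=C(c1ccc(F)cc1)N1CC(c2nc(-c3cccc(Cl)c3)no2)C1` differs from compound 3 by 4-fluorophenyl in place of 4-methylcyclohexyl on a carbonyl carbon. Among the compounds with values here, no measured pair covers this change; compound 1 carries an aromatic group at the same carbonyl and still sits at the limit, so no step beyond the scatter is expected. Compound 4 is expected at 9000 nM, between 2500 nM and 30000 nM, the expected step being an at least 1.1-fold lower number from compound 3 to compound 4 (0.04 log units; that floor lies within the scatter).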

Compound 4, half-maximal inhibitory concentration: 4000 nM
Beside the measured number, compound 4's estimate is 2.3-fold (0.35 log units) above it, within the range that was stated.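

Going by these compounds alone, the group on this carbonyl carbon matters: 4-fluorophenyl in place of 4-methylcyclohexyl gives an at least 2.5-fold lower number from compound 3 to compound 4 (0.39 log units; beyond the scatter), the first step between compounds differing in one place in this assay. The step starts from a limit, that of compound 3, so its full size stays unfixed: the limit of > 10000 nM in this assay, at which 2 of the 4 values shown sit.

Open, going by these compounds, is how an amine or a longer chain on this carbonyl carbon would read. Also open, on these data alone, is whether the same change would give a step of this kind on the core of compound 2.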